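Compound 1 to compound 3: a dichlorophenyl exchange

The compounds below may be only part of what the source reports. "The series", "measured", "known", "first", "only" and "open" are said of these compounds alone.

Among the measured compounds shown here, in a functional assay on HepG2 cells (Homo sapiens) for cytotoxicity, read by MTT assay, with a stated time of 24 h (a higher number here means a weaker inhibitor, a lower number a stronger inhibitor), compound 1 (`CN1C/C(=C\c2cccc([N+](=O)[O-])c2)C(=O)/C(=C/c2ccccc2F)C1`) gives 1080 nM and holds the lower of the two numbers so far. Compound 2 (`COc1cc(/C=C2\CN(C)C/C(=C\c3ccc(Cl)c(Cl)c3)C2=O)cc(OC)c1OC`) gives 6960 nM and lies beyond the scatter from compound 1. Compound 3 (`CN1C/C(=C\c2cccc([N+](=O)[O-])c2)C(=O)/C(=C/c2ccc(Cl)c(Cl)c2)C1`) keeps the core of compound 1 and has 3,4-dichlorophenyl in place of 2-fluorophenyl on a double-bonded chain carbon bound to a double-bonded ring carbon. For the measured compounds named here, no measured pair isolates this exchange. Compound 2 also carries 3,4-dichlorophenyl, and its 6960 nM points toward a higher number, but it differs from compound 3 elsewhere too, so only a modest rise is expected in this assay. The estimated change is a 2.1-fold higher number from compound 1 to compound 3 (0.33 log units; beyond the scatter) toward a weaker inhibitor. Compound 3 is expected at 2300 nM with an estimated range from 800 nM to 6500 nM in this read-out.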

Compound 3, half-maximal inhibitory concentration: 5960 nM
Beside the measured number, compound 3's estimate is 2.6-fold (0.41 log units) below it, within the range that was stated.
By their numbers in this assay, from the lowest: compound 1; then compounds 3 and 2 (each within the scatter of the next).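

In this assay, the position on a double-bonded chain carbon bound to a double-bonded ring carbon now has its first single-exchange reading: 3,4-dichlorophenyl in place of 2-fluorophenyl gives a 5.5-fold higher number from compound 1 to compound 3 (0.74 log units; beyond the scatter), toward a weaker inhibitor. The number at this position therefore depends on which of these two groups it carries, something compounds 1 and 2 could not show, as they differ in more than one place. No measured evidence bears on the reason for this step.

With only these two groups read here, the step cannot be assigned to gaining the chlorines or to losing the fluorine. On these data alone, how an unsubstituted phenyl, a pyridine ring or a phenyl bearing an amine would sit relative to these numbers remains open.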